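The compounds below may be only part of what the source reports. "The series", "measured", "known", "first", "only" and "open" are said of these compounds alone.

In a functional assay on NCI-H460 cells (Homo sapiens) for cytotoxicity, read by MTT assay, with a stated time of 72 h (on this read-out higher numbers stand for weaker inhibition and lower numbers for stronger inhibition), three compounds that differ only in one group on an aromatic carbon have been measured. Compound 1 `Cc1ccc(S(=O)(=O)n2cc(COC3=C/C(=N\c4ccc(I)cc4)c4ccccc4C3=O)nn2)cc1`, which carries iodo, gives only a limit, > 16300 nM. Compound 2 `Cc1ccc(S(=O)(=O)n2cc(COC3=C/C(=N\c4ccc(Br)cc4)c4ccccc4C3=O)nn2)cc1`, with bromo, gives 9410 nM, and compound 3 `Cc1ccc(S(=O)(=O)n2cc(COC3=C/C(=N\c4ccc(F)cc4)c4ccccc4C3=O)nn2)cc1`, with fluoro, gives 7360 nM. Compound 3 therefore cannot be separated from its bromo analogue, as the measured change, a 1.3-fold lower number from compound 2 to compound 3 (0.11 log units; within the scatter), shows.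

Compound 4 `COc1ccc(/N=C2\C=C(OCc3cn(S(=O)(=O)c4ccc(C)cc4)nn3)C(=O)c3ccccc32)cc1` has methoxy in place of fluoro on an aromatic carbon, para to a large group: methoxy in place of fluoro on an aromatic carbon. Among the compounds with values here, three measured steps bear on this change, all of them swaps at that same carbon, and none of them introduces methoxy. Two start from the limit and so give only floors: an at least 1.7-fold lower number from compound 1 to compound 2 (0.23 log units; that floor lies within the scatter) and an at least 2.2-fold lower number from compound 1 to compound 3 (0.34 log units; beyond the scatter). Within the data shown here, the only step between two real numbers is the small one already noted, so the evidence offers no clear reason to expect a large shift from compound 3. No step beyond the scatter is expected, and the estimated change is a 1.2-fold higher number from compound 3 to compound 4 (0.09 log units; within the scatter). For compound 4 the expected value is 9000 nM, with an estimated range of 3500 nM to 20000 nM.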

Compound 4, half-maximal inhibitory concentration: 8390 nM
Estimate against measurement, compound 4: 1.1-fold (0.03 log units) above; the measured number falls inside the stated range.
By their numbers in this assay, from the lowest: compounds 3, 4 and 2 (each within the scatter of the next). At a limit, above all of these: compound 1.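

In this assay, within the data shown here, compound 4 puts a methoxy at this position, a group with a hydrogen-bond acceptor and two heavy atoms, where the earlier compounds carry only single halogen atoms, and the step is a 1.1-fold higher number from compound 3 to compound 4 (0.06 log units; within the scatter). Set against the bromo analogue, the same group gives a 1.1-fold lower number from compound 2 to compound 4 (0.05 log units; within the scatter), so compounds 2, 3 and 4 cannot be told apart, and the series now holds a non-halogen group that stays level with fluoro and bromo. Against iodo the step reads an at least 1.9-fold lower number from compound 1 to compound 4 (0.28 log units; that floor lies within the scatter), which is only a floor, since compound 1 gives a limit and not a number: the limit of > 16300 nM in this assay, at which 1 of the 4 values shown sits.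

As far as these compounds go, whether compound 4 truly differs from compound 1 therefore stays open, and so does whether iodo stands apart from the other three groups at all. Also open, from the compounds shown here alone, is whether a different group at this position, such as an amine, a carboxylic acid or a longer alkoxy chain, would give a number clearly apart from those of compounds 2, 3 and 4.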